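The source may report more compounds than this note shows. Statements on the series, on what has been measured and on what is new or still open speak of the compounds shown alone.

Compound 2 `CN(c1cc2ncc(=O)[nH]c2cc1Nc1nc(-c2ccc(C#N)cc2)cs1)C1CCCCC1` was tested in an ADME assay on Huh-7 cells (Homo sapiens) for cytotoxicity (a lower number here means a stronger inhibitor, a higher number a weaker inhibitor), where compound 2 gives 18100 nM. For the measured compounds named here, only one other compound has been measured alongside it, compound 1 `CN(c1cc2ncc(=O)[nH]c2cc1Nc1nc(-c2ccc(Cl)cc2)cs1)C1CCCCC1`, which in this assay gives 16700 nM. The two differ in a single place, cyano in place of chloro on an aromatic carbon, and that step, a 1.1-fold higher number from compound 1 to compound 2 (0.03 log units; within the scatter), is too small to tell them apart, so compound 2 stands at the same level as compound 1 rather than apart from it.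

Compound 3 `CN(c1cc2ncc(=O)[nH]c2cc1Nc1nc(-c2ccc(-c3ccccc3)cc2)cs1)C1CCCCC1` has not yet been measured. It takes compound 2 and changes one place: phenyl in place of cyano on an aromatic carbon. Going by the values given here, the one measured step that bears on this, a swap of groups at the same place, a 1.1-fold higher number from compound 1 to compound 2 (0.03 log units; within the scatter), did not move the number beyond the scatter. With only that to go on, no shift beyond the scatter is expected for compound 3 in this assay, and the expected step is a 1.1-fold lower number from compound 2 to compound 3 (0.03 log units; within the scatter). Compound 3 is therefore estimated at 17000 nM, with a range from 8000 nM to 36000 nM.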

Compound 3, half-maximal inhibitory concentration: 82000 nM
Compound 3: middle estimate off by 4.8-fold (0.68 log units), on the low side; the whole stated range lies below it.
By their numbers in this assay, from the lowest: compounds 1 and 2 (each within the scatter of the next); then compound 3.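

The swap from chloro to cyano left the number unchanged within the scatter, but this assay does respond to a change at this position: phenyl gives a 4.5-fold higher number from compound 2 to compound 3 (0.66 log units; beyond the scatter) and a 4.9-fold higher number from compound 1 to compound 3 (0.69 log units; beyond the scatter), both beyond the scatter. Since a higher number here means a weaker inhibitor, the position on this six-membered aromatic ring is not indifferent to the group it carries, and phenyl, with six heavy atoms and a ring of its own, sets compound 3 apart from the other two compounds. No measurement available here accounts for this shift.

The compounds shown leave open whether the higher number follows the added ring or simply the greater number of atoms, a question that a butyl chain or a cyclohexyl ring at the same place could help to settle. They also leave open how an amine or a carboxylic acid would behave at this position, and whether phenyl would have the same effect on a different core.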